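The compounds below may be only part of what the source reports. "The series", "measured", "known", "first", "only" and "open" are said of these compounds alone.

Measured so far in a functional assay on PC-12 cells (Rattus norvegicus) for cytotoxicity, read by MTT assay, with stated times of 3 h and 2 h, tested at 0.1 uM; a higher number here means a stronger effect of the compound at the concentration tested, a lower number a weaker effect:

Compound 1 `O=C(CCCCC1CCSS1)NCc1cn(CCCCCOc2ccc3ccc(=O)oc3c2)nn1` gives 46.3%.
Compound 2 `CC(=O)c1cc2ccc(OCCCCCn3cc(CNC(=O)CCCCC4CCSS4)nn3)cc2oc1=O` gives 28.9%.
Compound 3 `COc1ccc(-c2cc3ccc(OCCCCCn4cc(CNC(=O)CCCCC5CCSS5)nn4)cc3oc2=O)cc1` gives 34.5%.

Compound 3 ranks second highest of these three numbers. Its number is lower than that of compound 1, as seen in a number 11.8 percentage points lower from compound 1 to compound 3 (beyond the scatter), while its gap to compound 2 is small, as seen in a number 5.6 percentage points higher from compound 2 to compound 3 (within the scatter).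

Compound 4 `O=C(CCCCC1CCSS1)NCc1cn(CCCCCOc2ccc3cc(-c4ccc(Cl)c(Cl)c4)c(=O)oc3c2)nn1` has not been tested. It differs from compound 3 in one place: 3,4-dichlorophenyl in place of 4-methoxyphenyl on an aromatic carbon. For the measured compounds named here, no measured pair swaps these two groups, so the expectation rests on what happened at the same place before. Adding a group there lowered the number modestly, as in a number 17.4 percentage points lower from compound 1 to compound 2 (beyond the scatter) and a number 11.8 percentage points lower from compound 1 to compound 3 (beyond the scatter), whereas exchanging one group for another there gave only a number 5.6 percentage points higher from compound 2 to compound 3 (within the scatter), a change inside the scatter. Compound 4 keeps a group of the same size at that place, so the step in this assay is expected to be within the scatter, with no clear direction.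

The estimate for compound 4 in this assay is therefore 33%, with a range from 22% to 45%, which means an expected step of a number 1.5 percentage points lower from compound 3 to compound 4 (within the scatter).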

Compound 4, a percentage reported as activity, at one concentration (the size of the read-out at that concentration, not a potency): 39.7%
For compound 4 the middle estimate is 6.7 percentage points below the measured one; the range from low to high includes it.
By their numbers in this assay, from the lowest: compounds 2, 3, 4 and 1 (each within the scatter of the next, the first and the last beyond it).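

In this assay the exchange of 4-methoxyphenyl for 3,4-dichlorophenyl gives a number 5.2 percentage points higher from compound 3 to compound 4 (within the scatter) and so does not separate the two phenyl groups, although one carries an oxygen and the other two chlorine atoms. The result also weakens the earlier picture in which every group placed here lowered the number: the data show a number 6.6 percentage points lower from compound 1 to compound 4 (within the scatter) and thus no clear loss against the hydrogen of compound 1, while they show a number 10.8 percentage points higher from compound 2 to compound 4 (beyond the scatter) and thus a clear gap to the acetyl compound, so the effect of a group at this place is not the same for all three groups. Nothing measured here accounts for these differences.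

At this place the compounds shown carry only hydrogen, acetyl and two substituted phenyl rings, so it stays open whether an amine, a carboxylic acid or a longer alkyl chain would give a number close to that of compound 1 or close to that of compound 2. On these data alone, with a single tested concentration, how these compounds compare at other concentrations also stays open.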